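Bridged bicyclic amine on the aryl ring of compound 3

A few compounds are considered here, and "the series" means these few. Any claim that something is new, unique, unknown or untested is made for them only; others in the source may bear on it.

Three compounds share one core and differ only in the saturated amine attached to an aromatic carbon. In a functional assay on CCRF-CEM cells for antagonist activity at C-X-C chemokine receptor type 4 (Homo sapiens), read by calcium flux, with stated times of 25 min and 90 s (on this read-out lower numbers stand for stronger inhibition and higher numbers for weaker inhibition), compound 1 `CN(C[C@H]1Cc2c(cccc2N2CCNC(C)(C)C2)CN1)[C@H]1CCCc2cccnc21` gives 33.9 nM, compound 2 `CC(C)N1CCN(c2cccc3c2C[C@H](CN(C)[C@H]2CCCc4cccnc42)NC3)CC1` gives 16.9 nM, and compound 3 `CN(C[C@H]1Cc2c(cccc2N2CCN3CCC[C@H]3C2)CN1)[C@H]1CCCc2cccnc21` gives 2.92 nM, the lowest number of the three; the steps of a 12-fold lower number from compound 1 to compound 3 (1.06 log units; beyond the scatter) and a 5.8-fold lower number from compound 2 to compound 3 (0.76 log units; beyond the scatter) both lie beyond the scatter, so compound 3 is the most potent of the measured set, while a 2.0-fold lower number from compound 1 to compound 2 (0.30 log units; within the scatter) stays within it. Compound 4 `CN(C[C@H]1Cc2c(cccc2N2C[C@@H]3C[C@H]2CN3)CN1)[C@H]1CCCc2cccnc21` is built by the change (a group of 7 heavy atoms (5 carbon, 2 nitrogen; 2 five-membered non-aromatic rings with 1 hetero atom each) in place of a group of 9 heavy atoms (7 carbon, 2 nitrogen; one five-membered non-aromatic ring with 1 hetero atom, one six-membered non-aromatic ring with 2 hetero atoms), on an aromatic carbon). Going by the values given here, no measured step swaps in this bridged pair of five-membered rings, so the only guide is that exchanging the amine in this position has moved this assay by large and modest amounts and that the fused bicycle of compound 3 stands out from the simpler piperazines. Compound 4 is therefore expected to fall somewhat back toward compounds 1 and 2, a step of a 3.4-fold higher number from compound 3 to compound 4 (0.53 log units; beyond the scatter), with an estimate of 10 nM and a likely range from 3 nM to 35 nM.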

Compound 4, half-maximal inhibitory concentration: 146 nM
The estimate for compound 4 lay 15-fold (1.16 log units) below the measured number; the whole stated range lies below it.
By their numbers in this assay, from the lowest: compound 3; then compounds 2 and 1 (each within the scatter of the next); then compound 4.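

Compound 3 and compound 4 both carry a two-ring amine on the aromatic carbon, yet the step is a 50-fold higher number from compound 3 to compound 4 (1.70 log units; beyond the scatter) in this assay, so a second ring alone does not give the strong inhibition seen with compound 3. The bridged group also does worse than the single-ring piperazines, with an 8.6-fold higher number from compound 2 to compound 4 (0.94 log units; beyond the scatter) and a 4.3-fold higher number from compound 1 to compound 4 (0.63 log units; beyond the scatter) as the steps. This makes compound 4 the weakest of the four and shows that this position can weaken inhibition as well as strengthen it.

From the compounds shown here alone, the change alters ring size, hydrogen-bond donor count and stereocentres together, so it remains open which of these matters, or whether a methyl group on the free ring nitrogen of compound 4 would restore inhibition. Nothing available explains the loss.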